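The source may report more compounds than this note shows. Statements on the series, on what has been measured and on what is new or still open speak of the compounds shown alone.

Compound 1 `CCOc1cc(=O)n(CCCO)c2c1CC(CC=C(C)C)C(C)(C)C2`: 66.5%
Compound 2 `CC(C)=CCC1Cc2c(OCCCNS(=O)(=O)c3ccc(Cl)cc3)cc(=O)n(CCCO)c2CC1(C)C`: 24.7%
Compound 3 `COc1ccc(C(=O)NCCCOc2cc(=O)n(CCCO)c3c2CC(CC=C(C)C)C(C)(C)C3)cc1`: 55.5%

These three compounds were tested in a functional assay on PANC-1 cells (Homo sapiens) for inhibition, read by MTT assay, with a stated time of 24 h, tested at 10 uM; on this read-out lower numbers stand for less inhibition and higher numbers for more inhibition at the one concentration tested (going by the name of the read-out). Compound 1 stands highest of the three numbers, with compound 3 nearest to it and compound 2 furthest away. The step to compound 4 `COc1cccc(NC(=O)Oc2cc(=O)n(CCCO)c3c2CC(CC=C(C)C)C(C)(C)C3)c1` is (3-methoxyphenyl)carbamoyl in place of ethyl on an oxygen on an aromatic ring. Among the compounds with values here, two measured steps bear on it, both of which enlarge what hangs from that ring oxygen: a number 41.8 percentage points lower from compound 1 to compound 2 (beyond the scatter) and a number 11 percentage points lower from compound 1 to compound 3 (beyond the scatter). Between those two products, a number 30.8 percentage points higher from compound 2 to compound 3 (beyond the scatter). Both measured additions lowered the read-out, so compound 4 is expected to come in under compound 1. For compound 4 the expected step is a number 21.5 percentage points lower from compound 1 to compound 4 (beyond the scatter). Compound 4 is estimated at 45%, with a range from 25% to 65%.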

Compound 4, a percentage reported as inhibition, at one concentration (the size of the read-out at that concentration, not a potency): 16.2%
Compound 4: the middle estimate sits 28.8 percentage points above what was measured; the whole stated range lies above it.
By their numbers in this assay, from the lowest: compounds 4 and 2 (each within the scatter of the next); then compound 3; then compound 1.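

In this assay, (3-methoxyphenyl)carbamoyl in place of ethyl gives a number 50.3 percentage points lower from compound 1 to compound 4 (beyond the scatter), even though this group sits directly on the ring oxygen, without the saturated chain carried by the two earlier products. All three larger groups at this oxygen therefore read under compound 1, and none of the compounds shown goes against that. Nothing measured here accounts for the drop. As far as these compounds go, whether a methyl or a butyl on that oxygen, or a free hydroxyl, would read above ethyl stays open.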